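Methoxy to Isopropoxy: A Dosing Question in Mice

The source may report more compounds than this note shows. Statements on the series, on what has been measured and on what is new or still open speak of the compounds shown alone.

Compound 1 `Oc1cccc(N2CCNCC2)n1` and compound 2 `COc1cccc(N2CCNCC2)n1` share one core and differ only at the oxygen on the aromatic ring. In a functional assay on the whole organism with Mus musculus as the target, in the maximal electroshock model, with a stated time of 30 min (a lower number here means that less compound is needed, a higher number that more compound is needed for the effect), compound 1 reaches only (the limit of > 300 mg/kg in this assay, at which 1 of the 2 values shown sits), so for compound 1 the reading > 300 mg/kg is a limit of the method and not a number. In this assay, for the measured compounds named here, compound 2 gives 30 mg/kg, the single number in this set, and the step of an at least 10-fold lower number from compound 1 to compound 2 (1.00 log units; beyond the scatter) is the only measured change available. Compound 3 `CC(C)Oc1cccc(N2CCNCC2)n1` now carries the change (isopropyl in place of methyl on an oxygen on an aromatic ring), which sits at the same oxygen as the measured step but swaps methyl for isopropyl rather than hydrogen for methyl. The earlier step shows that adding carbon at this oxygen was tolerated and helpful, yet it does not show how a branched group of three carbons would behave. The expectation is therefore cautious: compound 3 is estimated to stay near compound 2, with the step of no change at the digits printed from compound 2 to compound 3 (within the scatter) expected to lie within the usual scatter. Compound 3 is estimated at 30 mg/kg, ranging from 10 mg/kg to 100 mg/kg.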

Compound 3, minimum effective dose: 30 mg/kg
Estimate against measurement, compound 3: no gap at the digits printed, and the stated range covers the measured number.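

In this assay, the oxygen on the aromatic ring carries a branched isopropyl group as well as it carries methyl, and the two cannot be told apart, with no change at the digits printed from compound 2 to compound 3 (within the scatter). The advantage over the free hydroxyl compound is therefore not tied to methyl alone, as isopropyl in place of hydrogen also gives an at least 10-fold lower number from compound 1 to compound 3 (1.00 log units; beyond the scatter). As far as these compounds go, both of these comparisons with the free hydroxyl compound share one caution, since the reading for compound 1 is a limit of the assay and not a number, so the true size of the step stays unknown: the limit of > 300 mg/kg in this assay, at which 1 of the 3 values shown sits.

The compounds shown leave open whether a longer chain, a benzyl group or a trifluoromethyl group on this oxygen would keep the effective dose at the level shared by the methyl and isopropyl ethers, or whether some larger group would lose it. They also leave open whether that shared reading would hold at other times after dosing, as all the values here come from a single stated time in a single model.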